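Compound 4: an isopropyl group added to compound 3

This account rests on a few compounds, and the source may have more. Where it says the series, first, only, none or still open, it means among the compounds named here.

Measured in a functional assay on HeLa cells (Homo sapiens) for cytotoxicity, read by MTT assay, with a stated time of 72 h (on this read-out lower numbers stand for stronger inhibition and higher numbers for weaker inhibition), so far:
Compound 1 `CC1=CCC[C@H]2[C@](C)(CC3=CC(=O)C=CC3=O)[C@@H](C)CC[C@]12C` gives 18100 nM
Compound 2 `CSCC[C@H](NC1=CC(=O)C=C(C[C@]2(C)[C@@H](C)CC[C@]3(C)C(C)=CCC[C@@H]23)C1=O)C(=O)O` gives 13900 nM
Compound 3 `CC1=CCC[C@H]2[C@](C)(CC3=CC(=O)C=C(NCC(=O)O)C3=O)[C@@H](C)CC[C@]12C` gives 19900 nM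

In this assay compound 3 stands within the scatter of both other compounds. Compound 4 `CC1=CCC[C@H]2[C@](C)(CC3=CC(=O)C=C(N[C@@H](C(=O)O)C(C)C)C3=O)[C@@H](C)CC[C@]12C` carries isopropyl in place of hydrogen on a saturated chain carbon bound to an amine nitrogen and a carbonyl carbon. The closest guide is a change at that same carbon, hydrogen in place of 2-(methylsulfanyl)ethyl, which gave a 1.4-fold higher number from compound 2 to compound 3 (0.16 log units; within the scatter) and so shows no real shift. Adding the whole amino-bearing group to the shared core also stayed small, with a 1.3-fold lower number from compound 1 to compound 2 (0.11 log units; within the scatter) and a 1.1-fold higher number from compound 1 to compound 3 (0.04 log units; within the scatter) as the two cases. No shift beyond the scatter is therefore expected, and the estimated step is a 1.2-fold lower number from compound 3 to compound 4 (0.09 log units; within the scatter) in this comparison. Compound 4 is estimated at 16000 nM (expected range 8000 nM to 30000 nM).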

Compound 4, half-maximal inhibitory concentration: 10900 nM
Compound 4: middle estimate off by 1.5-fold (0.17 log units), on the high side; low and high end bracket the measured number.
By their numbers in this assay, from the lowest: compounds 4, 2, 1 and 3 (each within the scatter of the next).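

In this assay, placing isopropyl on the saturated chain carbon bound to an amine nitrogen and a carbonyl carbon stays within the scatter (a 1.8-fold lower number from compound 3 to compound 4 (0.26 log units; within the scatter)), so a second side chain at this carbon, after 2-(methylsulfanyl)ethyl, also brings no real shift. The same holds against compound 2 (a 1.3-fold lower number from compound 2 to compound 4 (0.11 log units; within the scatter)) and against the shared core without the amino-bearing group (a 1.7-fold lower number from compound 1 to compound 4 (0.22 log units; within the scatter)). Still open, as far as these compounds go, is whether a phenyl group at this carbon, or a methyl ester in place of the carboxylic acid, would move the number beyond the scatter. No measurement offers an explanation for these small steps.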